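Removing one methoxy group from compound 2, the acid with the lowest number

A few compounds are considered here, and "the series" means these few. Any claim that something is new, unique, unknown or untested is made for them only; others in the source may bear on it.

Compound 1 `COc1ccc(OC)c(-c2cn(-c3ccc(O)c(C(=O)Nc4cccc(C(F)(F)F)c4)c3)nn2)c1`: 15%
Compound 2 `COc1ccc(OC)c(-c2cn(-c3ccc(O)c(C(=O)O)c3)nn2)c1`: 9%
Compound 3 `COc1cc(OC)cc(-c2cn(-c3ccc(O)c(C(=O)Nc4cccc(C(F)(F)F)c4)c3)nn2)c1`: 73%

In a functional assay on CCRF-CEM cells (Homo sapiens) for inhibition, read by MTT assay, with a stated time of 2 days, tested at 10 uM (a lower number here means less inhibition, a higher number more inhibition at the concentration tested (going by the name of the read-out)), compound 2 gives the lowest of the three numbers, with compound 1 nearby, and compound 3 far above. The unmeasured compound 4 `COc1ccccc1-c1cn(-c2ccc(O)c(C(=O)O)c2)nn1` differs from compound 2 by hydrogen in place of methoxy on an aromatic carbon. For the measured compounds named here, no measured step removes a methoxy group, so none bears on it directly. The step of a number 58 percentage points higher from compound 1 to compound 3 (beyond the scatter) shows that the placement of the two methoxy groups can matter greatly, while a number 6 percentage points lower from compound 1 to compound 2 (within the scatter) changed the other end of the molecule with little effect. Going by the values given here, with no direct precedent, the expected step of a number 3 percentage points higher from compound 2 to compound 4 (within the scatter) is small, in no clear direction beyond the scatter. Compound 4 is therefore estimated at 12%, within 0% to 40%.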

Compound 4, a percentage reported as inhibition, at one concentration (the size of the read-out at that concentration, not a potency): 9%
Estimate against measurement, compound 4: 3 percentage points above; low and high end bracket the measured number.
By their numbers in this assay, from the lowest: compounds 2, 4 and 1 (each within the scatter of the next); then compound 3.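

In this assay, for the compounds shown here, the swap of hydrogen for methoxy on this aromatic carbon gives no change at the digits printed from compound 2 to compound 4 (within the scatter) and so offers the first direct reading of this position. For this acid, the methoxy group is not needed to keep the number where it stands, although that number is already low and a further loss would be hard to see. Nothing available explains this result.

From the compounds shown here alone, whether the same removal would change the much higher number of an amide such as compound 3 remains open. So does the effect of an amine or a longer chain such as ethoxy at this position.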